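A few compounds are considered here, and "the series" means these few. Any claim that something is new, unique, unknown or untested is made for them only; others in the source may bear on it.

Compound 3 `CC(C)=CCOc1cccc2ccc(N)nc12` sits at the edge of what the numbers here can show. In an assay on cells with melanin-concentrating hormone receptor 1 (Homo sapiens) as the target, read by radioligand binding (a higher number here means a weaker inhibitor, a lower number a stronger inhibitor), compound 3 gives > 2000 nM, which is a limit of the assay and not a number (the limit of > 2000 nM in this assay, at which 1 of the 3 values shown sits). For comparison, compound 1 `CCC(C)COc1cccc2ccc(N)nc12` gives 36 nM and compound 2 `CC1CC1COc1cccc2ccc(N)nc12` gives 1640 nM in this assay. The step to compound 4 `CCOCC(C)Oc1cccc2ccc(N)nc12` is a group of 6 heavy atoms (5 carbon, 1 oxygen; no ring) in place of a group of 5 heavy atoms (5 carbon; no ring), on an oxygen on an aromatic ring. Going by the values given here, two measured steps touch compound 3: an at least 55-fold higher number from compound 1 to compound 3 (1.74 log units; beyond the scatter) and an at least 1.2-fold higher number from compound 2 to compound 3 (0.08 log units; that floor lies within the scatter). Neither removes the double bond or brings in an ether oxygen, so they fix only where compound 3 starts, not where compound 4 lands. Compound 4 is therefore expected to give 800 nM in this assay, between 120 nM and 5000 nM, an estimated at least 2.5-fold lower number from compound 3 to compound 4 (0.39 log units; beyond the scatter).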

Compound 4, half-maximal inhibitory concentration: 1070 nM
Estimate against measurement, compound 4: 1.3-fold (0.13 log units) below, and the stated range covers the measured number.
By their numbers in this assay, from the lowest: compound 1; then compounds 4 and 2 (each within the scatter of the next). At a limit, above all of these: compound 3.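

On an oxygen on an aromatic ring, the only group shown with a hydrogen-bond acceptor stays far from the lowest number in this assay: a 30-fold higher number from compound 1 to compound 4 (1.47 log units; beyond the scatter). It does not separate from the group with the three-membered ring, a 1.5-fold lower number from compound 2 to compound 4 (0.19 log units; within the scatter), and the comparison with the group with the double bond gives only a floor, an at least 1.8-fold lower number from compound 3 to compound 4 (0.27 log units; that floor lies within the scatter). Compound 3 stands at a limit of the assay, > 2000 nM.

The compounds shown leave open whether an amine or a carboxylic acid on this chain would give a lower number. They also leave open how a longer chain without the oxygen would compare.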